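Removing a Chloro Group: What to Expect for Compound 4

The source may hold more compounds than are shown below. What is called first, only, known or untested is meant among the compounds shown, and "the series" means these compounds.

Three compounds have been examined in a functional assay on HFL1 cells (Homo sapiens) for inhibition, read by sulforhodamine B assay, with a stated time of 48 h (a lower number here means a smaller maximal response, a higher number a larger maximal response), and a fourth awaits measurement. Compound 1, `O=C1N=C(Nc2ccc(O)cc2)S/C1=C\C=C/c1ccccc1`, gave "not determined" (no result reported) in this assay. Compound 2, `COc1ccccc1NC(=O)CSc1nnc(NC2=NC(=O)/C(=C/c3ccc(Cl)cc3)S2)s1`, reached 17.4%. Compound 3, `O=C1N=C(Nc2ccc(O)cc2)S/C1=C\c1ccc(Cl)cc1`, reached 46.1%. Of the two numbers that exist, compound 3 stands higher, and the gap between compound 2 and compound 3 lies beyond the usual scatter of this assay, while compound 1 contributes no number at all.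

Compound 4, `O=C1N=C(Nc2ccc(O)cc2)S/C1=C\c1ccccc1`, has not yet been measured. It differs from compound 3 in a single place: hydrogen in place of chloro on an aromatic carbon. Going by the values given here, no pair of measured compounds shows the effect of this particular change on its own, so the expectation rests on compound 3 alone and on how little of the structure is altered, since only the chloro group is removed and nothing new enters beyond a hydrogen.

With so small a change, the step in this assay is expected to be modest, a slight move toward a lower value that may not exceed the scatter, estimated as a number 8.1 percentage points lower from compound 3 to compound 4 (within the scatter). Compound 4 is therefore estimated to reach 38% in this assay, within a range from 20% to 58%.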

Compound 4, largest response reached (Emax), in percent of the reference or control that the assay uses: 23.8%
Beside the measured number, compound 4's estimate is 14.2 percentage points above it, within the range that was stated.
By their numbers in this assay, from the lowest: compounds 2 and 4 (each within the scatter of the next); then compound 3.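

In this assay, going by these compounds alone, replacing 4-chlorophenyl with phenyl gives the only single-change comparison available here, a step of a number 22.3 percentage points lower from compound 3 to compound 4 (beyond the scatter). This shows that the chloro group at this place matters for the maximal response: removing one chlorine atom, with no ring, hydrogen-bond donor, hydrogen-bond acceptor or net charge involved in the change, moves the value by more than the usual scatter. The data shown offer no measurement that explains why this step occurs.

The compounds shown leave open how other groups at this same place, such as fluoro, methyl, an amine or a carboxylic acid, would compare with chloro and hydrogen, so a single step cannot establish a trend for this position. They also leave open whether removing chloro would give a step of similar size when the rest of the molecule differs, as in a relative of compound 2, which carries the same 4-chlorophenyl group on a much larger structure.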